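The source may hold more compounds than are shown below. What is called first, only, known or untested is meant among the compounds shown, and "the series" means these compounds.

Among the measured compounds shown here, in a functional assay on HT-29 cells (Homo sapiens) for inhibition, read by sulforhodamine B assay, with a stated time of 48 h (a lower number here means a stronger inhibitor of growth, a higher number a weaker inhibitor of growth), two compounds have numbers so far. Compound 1 (`CCOC(=O)C1=C(C)NC(=O)NC1c1ccc(SC)cc1`) gives 10.2 ug/mL, the lower of the two, while compound 2 (`CCOC(=O)C1=C(C)NC(=S)NC1c1cccc(OC)c1`) gives 28.3 ug/mL, and this gap lies beyond the usual scatter. Compound 1 is therefore the stronger inhibitor of growth of the two. Compound 3 (`CCOC(=O)C1=C(C)NC(=O)NC1c1ccc(O)cc1`) keeps the core of compound 1 but carries hydroxy in place of methylsulfanyl on an aromatic carbon, para to a large group: hydroxy in place of methylsulfanyl on an aromatic carbon. For the measured compounds named here, no measured pair shows a change at this place, so the expectation starts from compound 1 at 10.2 ug/mL and stays loose. A modest move towards weaker inhibition is expected, near the edge of the scatter. The expected step is a 2.0-fold higher number from compound 1 to compound 3 (0.29 log units; within the scatter). For compound 3 the estimated value is 20 ug/mL, with an expected range from 8 ug/mL to 55 ug/mL.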

Compound 3, concentration for 50% growth inhibition: 28.7 ug/mL
Compound 3: the middle estimate sits 1.4-fold (0.16 log units) below what was measured; the range from low to high includes it.
By their numbers in this assay, from the lowest: compound 1; then compounds 2 and 3 (each within the scatter of the next).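

Among the compounds shown here, this is the first step at this position. In this assay, hydroxy in place of methylsulfanyl on an aromatic carbon, para to a large group, gives a 2.8-fold higher number from compound 1 to compound 3 (0.45 log units; beyond the scatter), a modest weakening of growth inhibition with the rest of compound 1 unchanged. The position is therefore not indifferent to the group it carries, although nothing shown here accounts for the difference between these two groups.

The compounds shown leave open how a methoxy group, an amine or a chlorine atom would compare at this same place, and so whether methylsulfanyl holds any advantage over groups other than hydroxy. They also leave open whether the same change would give a step of similar size on a different core.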